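This account rests on a few compounds, and the source may have more. Where it says the series, first, only, none or still open, it means among the compounds named here.

Compound 1 `COc1ccc(/C=C/C(=O)Nc2cc(C(=O)c3cc(OC)c(OC)c(OC)c3)ccc2OC)cc1` gives 5010 nM in a functional assay on HT-29 cells (Homo sapiens) for cytotoxicity, read by MTT assay, with a stated time of 72 h; on this read-out higher numbers stand for weaker inhibition and lower numbers for stronger inhibition. Within the data shown here, compound 2 `COc1cccc(/C=C/C(=O)Nc2cc(C(=O)c3cc(OC)c(OC)c(OC)c3)ccc2OC)c1` gives 1900 nM in this assay, the lower of the two numbers; the only step known, a 2.6-fold lower number from compound 1 to compound 2 (0.42 log units; beyond the scatter), is modest yet beyond the scatter. Compound 3 `COc1ccc(C(=O)c2cc(OC)c(OC)c(OC)c2)cc1NC(=O)/C=C/c1ccc(F)cc1` differs from compound 2 by 4-fluorophenyl in place of 3-methoxyphenyl on a double-bonded chain carbon bound to a double-bonded chain carbon. Among the measured compounds shown here, no measured step covers this change; that single step shows only that relocating the methoxy on this ring shifts this assay modestly, so a step of comparable size in either direction, or none beyond the scatter, is what one can reasonably expect. Compound 3 is therefore estimated at 3000 nM, between 900 nM and 10000 nM, an expected step of a 1.6-fold higher number from compound 2 to compound 3 (0.20 log units; within the scatter).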

Compound 3, half-maximal inhibitory concentration: 1800 nM
Estimate against measurement, compound 3: 1.7-fold (0.22 log units) above; low and high end bracket the measured number.
By their numbers in this assay, from the lowest: compounds 3 and 2 (each within the scatter of the next); then compound 1.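

In this assay, 4-fluorophenyl in place of 3-methoxyphenyl on this double-bonded chain carbon brings a 1.1-fold lower number from compound 2 to compound 3 (0.02 log units; within the scatter), so a methoxy on this ring is not required to reach this level. Fluoro in place of methoxy on the aromatic carbon of the 4-methoxyphenyl ring gives a 2.8-fold lower number from compound 1 to compound 3 (0.44 log units; beyond the scatter), so at that ring carbon the choice of group does register in this read-out. Nothing available explains either step. From the compounds shown here alone, it remains open how 3-fluorophenyl, 4-chlorophenyl, unsubstituted phenyl or 4-aminophenyl would read at this place.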